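The compounds below may be only part of what the source reports. "The series", "measured", "known", "first", "only" and "open" are said of these compounds alone.

Compound 1 `COc1cccc(NC(=O)Nc2ccc(Oc3ncnc4[nH]ncc34)cc2)c1` belongs to a set of three ureas that share one core and differ only in the aryl group on an amide-type nitrogen. In an assay on isolated protein for inhibition of vascular endothelial growth factor receptor 2 (Danio rerio), read by fluorescence and microscopy, with a stated time of 33 h (a lower number here means a stronger inhibitor, a higher number a weaker inhibitor), compound 1 gives 82000 nM, the second highest of the three numbers. Compound 2 `Cc1cccc(NC(=O)Nc2ccc(Oc3ncnc4[nH]ncc34)cc2)c1C` gives 98800 nM, and a 1.2-fold higher number from compound 1 to compound 2 (0.08 log units; within the scatter). Compound 3 `O=C(Nc1ccc(Oc2ncnc3[nH]ncc23)cc1)Nc1ccc(C(F)(F)F)cc1` gives 1200 nM, with a 68-fold lower number from compound 1 to compound 3 (1.83 log units; beyond the scatter) and an 82-fold lower number from compound 2 to compound 3 (1.92 log units; beyond the scatter). Compound 4 `COc1cccc(NC(=O)Nc2ccc(Oc3ncnc4c3cnn4C)cc2)c1` differs from compound 1 by methyl in place of hydrogen on an aromatic nitrogen. Among the measured compounds shown here, no measured step touches that part of the core; all three vary only the aryl group on the urea, so they offer no guide to the size or direction of this change. Compound 4 is therefore expected to stay near compound 1, with a 1.2-fold higher number from compound 1 to compound 4 (0.09 log units; within the scatter) likely within the scatter. The estimate for compound 4 is 100000 nM, with a range from 35000 nM to 300000 nM.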

Compound 4, half-maximal inhibitory concentration: > 100000 nM
Compound 4: no number, only a limit; the forecaster's own chance of this, stated with the estimate: 25%; the middle value lies on the limit itself.
By their numbers in this assay, from the lowest: compound 3; then compounds 1 and 2 (each within the scatter of the next). At a limit, above all of these: compound 4.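

In this assay, compound 4 gives a limit of the assay rather than a number: the limit of > 100000 nM in this assay, at which 1 of the 4 values shown sits. Methyl in place of hydrogen on the aromatic nitrogen, the first change shown on the shared core rather than on the urea aryl group, gives an at least 1.2-fold higher number from compound 1 to compound 4 (0.08 log units; that floor lies within the scatter). As far as these compounds go, this change therefore brings no lower number, but its true size remains unknown.

From the compounds shown here alone, it remains open whether the same methyl would shift the much lower number of compound 3, and what a longer chain such as ethyl would give on this nitrogen.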